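This account rests on a few compounds, and the source may have more. Where it says the series, first, only, none or still open, it means among the compounds named here.

Measured so far:
compound 1, `Nc1nc(N2CCN(C(=O)COc3ccc(F)cc3)CC2)c2nc(-c3ccc(F)cc3)sc2n1`: 70 nM
compound 2, `Nc1nc(N2CCN(C(=O)COc3ccc(Cl)cc3)CC2)c2nc(-c3cccnc3)sc2n1`: 50 nM

Both compounds were tested in a functional assay on cells (Lymphocyte, Homo sapiens); on this read-out lower numbers stand for stronger inhibition and higher numbers for weaker inhibition. Compound 2 has the lowest of the two numbers, but compound 1 sits within the usual scatter of it, so no order between the two can be read from this pair. Compound 3, `Nc1nc(N2CCN(C(=O)COc3ccc(F)cc3)CC2)c2nc(-c3cccnc3)sc2n1`, has not yet been measured in this assay. It differs from compound 2 in one place: fluoro in place of chloro on an aromatic carbon. Compound 1 already carries the 4-fluorophenoxy group that enters here, though it differs from compound 3 elsewhere as well, so its value can only serve as a loose hint; what the two measured values show is that two compounds with different substituents on this ring land within the scatter of each other. Among the measured compounds shown here, no step between measured compounds isolates this single change. The expectation for this assay is therefore a step of no real size, with no direction beyond the scatter. For compound 3 the estimate is 60 nM, with a range from 30 nM to 130 nM, which corresponds to an expected step of a 1.2-fold higher number from compound 2 to compound 3 (0.08 log units; within the scatter).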

Compound 3, half-maximal inhibitory concentration: 12 nM
For compound 3 the middle estimate is 5.0-fold (0.70 log units) above the measured one, outside the stated range (below it).
By their numbers in this assay, from the lowest: compound 3; then compounds 2 and 1 (each within the scatter of the next).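

In this assay, fluoro in place of chloro on the phenoxy ring, with the rest of the molecule unchanged, gives a 4.2-fold lower number from compound 2 to compound 3 (0.62 log units; beyond the scatter), so a single atom at this ring position makes a real difference to the read-out, something the earlier pair could not show since its two members differ in two places at once. Keeping the 4-fluorophenoxy group fixed and placing pyridin-3-yl where 4-fluorophenyl stood gives a 5.8-fold lower number from compound 1 to compound 3 (0.77 log units; beyond the scatter), so the group at the other end of the molecule matters as well, and the closeness of the first two compounds hid both effects. Nothing available here explains why either change shifts the number.

From the compounds shown here alone, at the phenoxy position only fluoro and chloro can be compared, so it remains open whether plain hydrogen, a methyl or a methoxy group there would give a lower or a higher number than fluoro. Going by these compounds, it is also open how chloro would behave alongside the 4-fluorophenyl group, and so whether the two steps simply add together or depend on each other.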